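From 2-methoxyphenyl to 2,4-dichlorophenyl at the assay limit

The source may report more compounds than this note shows. Statements on the series, on what has been measured and on what is new or still open speak of the compounds shown alone.

Compound 1 `OC[C@H]1O[C@@H](n2cnc3c(NCc4ccc(Cl)cc4)ncnc32)[C@H](O)[C@@H]1O`: > 166000 nM, a limit
Compound 2 `COc1ccccc1CNc1ncnc2c1ncn2[C@@H]1O[C@H](CO)[C@@H](O)[C@H]1O`: > 166000 nM, a limit

Both entries come from a functional assay on G-361 cells (Homo sapiens) for antiproliferative activity, with a stated time of 72 h; on this read-out higher numbers stand for weaker inhibition and lower numbers for stronger inhibition. Compound 2 has no exact value, only a limit, as the limit of > 166000 nM in this assay, at which 2 of the 2 values shown sit, shows. Compound 3 `OC[C@H]1O[C@@H](n2cnc3c(NCc4ccc(Cl)cc4Cl)ncnc32)[C@H](O)[C@@H]1O` differs from it as follows: 2,4-dichlorophenyl in place of 2-methoxyphenyl on a saturated chain carbon bound to a nitrogen on an aromatic ring. Going by the values given here, the one measured step bearing on this change is a step that the two limits leave unreadable from compound 1 to compound 2, so it gives no size to carry over. With no measured number showing activity, the expected change is none beyond the scatter, and the estimated step is a number no higher from compound 2 to compound 3 (the limit leaves the size open). Compound 3 is expected to stay near the limit, at an estimated 166000 nM, within an expected range of 70000 nM to 300000 nM.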

Compound 3, half-maximal inhibitory concentration: 128000 nM
Beside the measured number, compound 3's estimate is 1.3-fold (0.11 log units) above it; low and high end bracket the measured number.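

In this assay, going by these compounds alone, the 2,4-dichlorobenzyl group gives the first exact number at this position, but the change from 2-methoxybenzyl is an at least 1.2-fold lower number from compound 2 to compound 3 (0.11 log units; that floor lies within the scatter), and chloro in place of hydrogen on an aromatic carbon is an at least 1.2-fold lower number from compound 1 to compound 3 (0.11 log units; that floor lies within the scatter). Neither step establishes a real gain, and the step between the two limits cannot be read. The other two compounds still have no exact value: the limit of > 166000 nM in this assay, at which 2 of the 3 values shown sit.

Open, as far as these compounds go, is whether a longer chain in place of the benzyl group, or an amine on its ring, would give a number well clear of this limit.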